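Removing the chloro group from compound 2

This account rests on a few compounds, and the source may have more. Where it says the series, first, only, none or still open, it means among the compounds named here.

In a functional assay on A549 cells (Homo sapiens) for inhibition (a lower number here means a stronger inhibitor, a higher number a weaker inhibitor), compound 1 (`CCN(C(=O)CC(CC(=O)NCCN1CCCCC1)c1ccc(Cl)cc1)C1Cc2ccccc2C1`) gives 13200 nM and compound 2 (`CCNCCNC(=O)CC(CC(=O)N(CC)C1Cc2ccccc2C1)c1ccc(Cl)cc1`) gives 19400 nM as its value, so the two compounds stand within the scatter of each other. The change to compound 3 (`CCNCCNC(=O)CC(CC(=O)N(CC)C1Cc2ccccc2C1)c1ccccc1`) is hydrogen in place of chloro on an aromatic carbon and reads as 4-chlorophenyl to phenyl. Among the compounds with values here, the only measured step is a 1.5-fold higher number from compound 1 to compound 2 (0.17 log units; within the scatter) and it has ethylamino in place of piperidin-1-yl, at another place in the molecule. Within the data shown here, no measured step covers the chloro position, so the series offers no direct guide to this change and no firm direction. No step beyond the scatter is expected, and the estimated step is a 1.3-fold higher number from compound 2 to compound 3 (0.11 log units; within the scatter) for now. For compound 3 the expected value in this assay is 25000 nM with an estimated range from 9000 nM to 60000 nM as its limits of expectation.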

Compound 3, half-maximal inhibitory concentration: > 100000 nM
Compound 3 was reported as a limit; the forecaster's own chance of this, stated with the estimate: 15%; at least 4.0-fold (0.60 log units) between middle value and limit.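

In this assay, within the data shown here, hydrogen in place of chloro gives the first step that lies beyond the scatter, an at least 5.1-fold higher number from compound 2 to compound 3 (0.71 log units; beyond the scatter), whereas the change elsewhere in the molecule, a 1.5-fold higher number from compound 1 to compound 2 (0.17 log units; within the scatter), stays within it. For compound 3 the read-out is a limit, > 100000 nM, and not a number. The full size of the step therefore stays unknown, but this position on the aromatic ring is so far the one place where a single change leads from a measurable value to the limit: the limit of > 100000 nM in this assay, at which 1 of the 3 values shown sits.

The compounds shown carry only chloro or hydrogen here, so it stays open whether fluoro, bromo or methoxy at this position would behave like chloro. From the compounds shown here alone, whether the step holds with piperidin-1-yl in place of ethylamino also stays open.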